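Swapping the chain end: from methyl to 4-methoxyphenyl

This account rests on a few compounds, and the source may have more. Where it says the series, first, only, none or still open, it means among the compounds named here.

Compound 1, `C/C=C1/[C@H](O[C@@H]2O[C@H](CO)[C@@H](O)[C@H](O)[C@H]2O)OC=C(C(=O)OC)[C@H]1CC(=O)OCCc1ccc(OC)c(OC)c1`, in a functional assay on SK-BR-3 cells (Homo sapiens) for antiproliferative activity, read by MTT assay, with a stated time of 72 h (on this read-out lower numbers stand for stronger inhibition and higher numbers for weaker inhibition), reaches only the limit > 15000 nM.
Compound 2, `C/C=C1/[C@H](O[C@@H]2O[C@H](CO)[C@@H](O)[C@H](O)[C@H]2O)OC=C(C(=O)OC)[C@H]1CC(=O)OCCC1CCCCC1`, in this assay gives 2000 nM.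
Compound 3, `C/C=C1/[C@H](O[C@@H]2O[C@H](CO)[C@@H](O)[C@H](O)[C@H]2O)OC=C(C(=O)OC)[C@H]1CC(=O)OCCC`, in this assay reaches only the limit > 15000 nM.

Compound 3 therefore stands at a limit of this assay rather than at a number, as marked by the limit of > 15000 nM in this assay, at which 2 of the 3 values shown sit. Compound 4, `C/C=C1/[C@H](O[C@@H]2O[C@H](CO)[C@@H](O)[C@H](O)[C@H]2O)OC=C(C(=O)OC)[C@H]1CC(=O)OCCc1ccc(OC)cc1`, differs from compound 3 in one place: 4-methoxyphenyl in place of methyl on a saturated chain carbon, two bonds along the chain from an oxygen next to a carbonyl group.

For the measured compounds named here, two measured steps bear on this. The step of an at least 7.5-fold higher number from compound 2 to compound 3 (0.87 log units; beyond the scatter) shows that cyclohexyl gave a readable number where methyl did not. The step that the two limits leave unreadable from compound 1 to compound 3 cannot be read, since both ends are limits, and the step of an at least 7.5-fold lower number from compound 1 to compound 2 (0.87 log units; beyond the scatter) shows that 3,4-dimethoxyphenyl sits no better than methyl. The 4-methoxyphenyl group of compound 4 resembles that aryl group more than cyclohexyl, so the expected step of a number no higher from compound 3 to compound 4 (the limit leaves the size open) is small and may not leave the limit. Compound 4 is estimated at 15000 nM, within 4000 nM to 40000 nM.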

Compound 4, half-maximal inhibitory concentration: > 20000 nM
Compound 4 ended at the assay's limit; the forecaster's own chance of this, stated with the estimate: 60%; middle value at least 1.3-fold (0.12 log units) from the limit.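

Compound 4 also ends at a limit rather than a number: the limit of > 20000 nM in this assay, at which 1 of the 4 values shown sits.

The steps from compound 3 and from compound 1 to compound 4 cannot be read, with limits at both ends, so neither 4-methoxyphenyl against methyl nor the loss of one methoxy from the aromatic ring can be sized. Set in place of cyclohexyl, 4-methoxyphenyl gives an at least 10-fold higher number from compound 2 to compound 4 (1.00 log units; beyond the scatter), so in this assay a second aromatic end group joins methyl at a limit, and among the four compounds only compound 2, with its cyclohexyl, gives a readable number.

On these data alone, whether a plain phenyl, a cyclopentyl or a longer straight chain at this position would also give a readable number remains open. Also open, as far as these compounds go, is whether adding a hydroxyl or an amine to the cyclohexyl ring would keep that number.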